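Aryl sulfonate ureas: iodo for isopropyl, second instance

A few compounds are considered here, and "the series" means these few. Any claim that something is new, unique, unknown or untested is made for them only; others in the source may bear on it.

Measured compounds in a functional assay on HT-1080 cells (Homo sapiens) for antiproliferative activity, read by sulforhodamine B assay, with a stated time of 48 h; on this read-out higher numbers stand for weaker inhibition and lower numbers for stronger inhibition:
compound 1 `CCCNC(=O)Nc1ccc(S(=O)(=O)Oc2ccccc2C(C)C)cc1` gives 680 nM
compound 2 `CCCNC(=O)Nc1ccc(S(=O)(=O)Oc2ccccc2I)cc1` gives 700 nM
compound 3 `CC(C)c1ccccc1OS(=O)(=O)c1ccc(NC(=O)NCC2CCCC2)cc1` gives 6000 nM

Compound 1 and compound 2 differ in one place, (iodo in place of isopropyl on an aromatic carbon). The step is a 1.0-fold higher number from compound 1 to compound 2 (0.01 log units; within the scatter), so the two values show nothing that can be told apart.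

Compound 3 carries the same aryl sulfonate as compound 1 but a different urea chain; the cores differ by cyclopentyl in place of ethyl on a saturated chain carbon bound to an amide-type nitrogen. That step is an 8.8-fold higher number from compound 1 to compound 3 (0.95 log units; beyond the scatter), and compound 3 has the highest number of the three measured.

Compound 4 `O=C(NCC1CCCC1)Nc1ccc(S(=O)(=O)Oc2ccccc2I)cc1` is not yet measured. It differs from compound 3 by iodo in place of isopropyl on an aromatic carbon, which is the same change as that from compound 1 to compound 2, now made on the core of compound 3.

Among the compounds with values here, the expectation for compound 4 rests on the one earlier instance: because a 1.0-fold higher number from compound 1 to compound 2 (0.01 log units; within the scatter) left the number essentially unchanged, the step from compound 3 to compound 4 is expected to be no change at the digits printed from compound 3 to compound 4 (within the scatter). Compound 4 is therefore estimated at 6000 nM in this assay, with a likely range from 3000 nM to 12000 nM.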

Compound 4, half-maximal inhibitory concentration: 6100 nM
The estimate for compound 4 lay 1.0-fold (0.01 log units) below the measured number, and the stated range covers the measured number.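

In this assay, iodo in place of isopropyl gives a 1.0-fold higher number from compound 3 to compound 4 (0.01 log units; within the scatter), and this step reads the same on both cores: the same change on two cores in this assay, a 1.0-fold higher number (0.01 log units; within the scatter) from compound 1 to compound 2 and a 1.0-fold higher number (0.01 log units; within the scatter) from compound 3 to compound 4, 1.0-fold (0.01 log units) apart, within the scatter of two such steps. Cyclopentyl in place of ethyl gives an 8.7-fold higher number from compound 2 to compound 4 (0.94 log units; beyond the scatter) with the 2-iodophenyl group present, and the chain step likewise reads the same with either aryl group: the same change on two cores in this assay, an 8.8-fold higher number (0.95 log units; beyond the scatter) from compound 1 to compound 3 and an 8.7-fold higher number (0.94 log units; beyond the scatter) from compound 2 to compound 4, 1.0-fold (0.01 log units) apart, within the scatter of two such steps. The two changes therefore behave independently across these four compounds, but this rests on two cores in a single assay, and it neither gives a reason for the match nor shows that the iodo and isopropyl groups would stay interchangeable on a core with a different urea chain.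

As far as these compounds go, it remains open whether the match extends to other groups on that aromatic carbon, such as bromo, methoxy or a nitrile. Also open, from the compounds shown here alone, is how the urea chain step would read with a cyclohexyl group, a phenyl group or a longer chain in place of cyclopentyl.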